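From Chloro to Cyano on a Weakly Cytotoxic Core

The source may hold more compounds than are shown below. What is called first, only, known or untested is meant among the compounds shown, and "the series" means these compounds.

Compound 2 `C=CC(=O)N1C(=O)CC(c2ccc(Cl)cc2)Sc2ccccc21` was tested in a functional assay on NB-4 cells (Homo sapiens) for cytotoxicity, read by CCK-8 assay, with a stated time of 24 h (a lower number here means a stronger inhibitor, a higher number a weaker inhibitor), where compound 2 gives 22600 nM. Among the compounds with values here, its only measured neighbour, compound 1 `C=CC(=O)N1C(=O)CC(c2ccc(C(=O)OC)cc2)Sc2ccccc21`, gives 24400 nM in this assay. The two numbers lie within the usual scatter of each other, so neither compound can be called the stronger inhibitor. Within the data shown here, the only measured step, a 1.1-fold lower number from compound 1 to compound 2 (0.03 log units; within the scatter), shows that exchanging one group on this aromatic carbon for another left the number essentially unchanged.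

Compound 3 `C=CC(=O)N1C(=O)CC(c2ccc(C#N)cc2)Sc2ccccc21` differs from compound 2 by cyano in place of chloro on an aromatic carbon. For this change no step beyond the scatter is expected in this assay, because a 1.1-fold lower number from compound 1 to compound 2 (0.03 log units; within the scatter) moved the number so little. Compound 3 is therefore expected to give 23000 nM, with a range from 10000 nM to 50000 nM. This corresponds to an estimated step of a 1.0-fold higher number from compound 2 to compound 3 (0.01 log units; within the scatter).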

Compound 3, half-maximal inhibitory concentration: 62400 nM
Estimate against measurement, compound 3: 2.7-fold (0.43 log units) below; the whole stated range lies below it.
By their numbers in this assay, from the lowest: compounds 2 and 1 (each within the scatter of the next); then compound 3.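

The group on this aromatic carbon can matter after all: in this assay cyano in place of chloro gives a 2.8-fold higher number from compound 2 to compound 3 (0.44 log units; beyond the scatter) and cyano in place of methoxycarbonyl gives a 2.6-fold higher number from compound 1 to compound 3 (0.41 log units; beyond the scatter) as well. Both steps are modest but lie beyond the scatter, which makes compound 3 the weakest inhibitor of the three, while compounds 1 and 2 stay level with each other. Nothing in the data shown says why cyano stands apart from the other two groups.

On these data alone, whether an amine, a carboxylic acid or a longer chain on this carbon would lower the number or raise it further remains open. Also open, as far as these compounds go, is whether the step from chloro to cyano would look the same on another aromatic carbon of the shared core.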